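The source may report more compounds than this note shows. Statements on the series, on what has been measured and on what is new or still open speak of the compounds shown alone.

The measured compounds are compound 1 `C=C(Br)C(=O)Nc1ccc(/C=C2\SC(=O)N(Cc3ccc(C)cc3)C2=O)cc1`, compound 2 `Cc1ccc(CN2C(=O)S/C(=C\c3cccc(N)c3)C2=O)cc1` and compound 3 `Nc1cccc(/C=C2\SC(=O)N(Cc3cccc(F)c3)C2=O)c1`. In a functional assay on CCRF-CEM cells (Homo sapiens) for cytotoxicity, read by cell counting, with a stated time of 3 days (on this read-out lower numbers stand for stronger inhibition and higher numbers for weaker inhibition), compound 1 gives 3700 nM. Compound 3 gives 250000 nM. For compound 2 the assay reports only a limit, > 250000 nM.

Compound 1 thus stands lowest of the two numbers shown; compound 3, the nearest of them, lies far higher, well beyond the scatter, and the remaining value of compound 2 is a limit rather than a number.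

The compound still to be measured is compound 4 `C=C(Br)C(=O)Nc1ccc(/C=C2\SC(=O)N(Cc3cccc(F)c3)C2=O)cc1`. It differs from compound 1 as follows: 3-fluorophenyl in place of 4-methylphenyl on a saturated chain carbon bound to an amide-type nitrogen in a ring. The same change has been made once before, from compound 2 to compound 3, giving a number no higher from compound 2 to compound 3 (the limit leaves the size open). Among the measured compounds shown here, because compound 2 sits at the limit of > 250000 nM in this assay, at which 1 of the 3 values shown sits, the size of that step cannot be read, and it says only that the change did not raise the number. For the measured compounds named here, no measured step therefore gives a usable size for this change, and the one example sits at the weak end of the assay, far from where compound 1 stands. The expectation for compound 4 is a step of about no change at the digits printed from compound 1 to compound 4 (within the scatter), that is, no change beyond the scatter. Compound 4 is accordingly estimated at 3700 nM, with a range from 1200 nM to 12000 nM.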

Compound 4, half-maximal inhibitory concentration: 3200 nM
Beside the measured number, compound 4's estimate is 1.2-fold (0.06 log units) above it, within the range that was stated.
By their numbers in this assay, from the lowest: compounds 4 and 1 (each within the scatter of the next); then compound 3.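

In this assay the change of 4-methylbenzyl to 3-fluorobenzyl now has a size that can be read, on the core of compound 1, with a 1.2-fold lower number from compound 1 to compound 4 (0.06 log units; within the scatter), a step within the scatter. At this place, on a saturated chain carbon bound to an amide-type nitrogen in a ring, the read-out therefore does not tell these two groups apart on that core, and a fluorine on the ring in place of the methyl group leaves the number where it was within the scatter. The earlier pair could not show this, as compound 2 holds only a limit, > 250000 nM.

Going by these compounds, whether the change acts alike on both cores stays open, because the step on the other core cannot be read: the same change on two cores in this assay, a number no higher (the limit leaves the size open) from compound 2 to compound 3 and a 1.2-fold lower number (0.06 log units; within the scatter) from compound 1 to compound 4; the limit leaves it open whether they differ Also open is how the number responds at this place to groups unlike these two benzyl groups, such as a longer chain ending in a carboxylic acid, or an amine on the ring in place of the fluorine.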